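The source may hold more compounds than are shown below. What is called first, only, known or untested is meant among the compounds shown, and "the series" means these compounds.

Compound 1 `O=C(CN1CN(c2ccccc2)C2(CCN(C(=O)c3ccc(C4CCCCC4)cc3)CC2)C1=O)N1CCCCC1` gives 1100 nM in an assay on HEK293 cells for displacement of a labelled ligand from NPC1-like intracellular cholesterol transporter 1 (Homo sapiens); a higher number here means a weaker inhibitor, a lower number a stronger inhibitor; compound 2 `O=C(CN1CN(c2ccccc2)C2(CCN(C(=O)c3ccc(C4CCCCC4)cc3)CC2)C1=O)NCO` gives 8300 nM, the highest of the two numbers, and the step of a 7.5-fold higher number from compound 1 to compound 2 (0.88 log units; beyond the scatter) was modest but beyond the scatter. Compound 3 `CS(=O)(=O)NCCNC(=O)CN1CN(c2ccccc2)C2(CCN(C(=O)c3ccc(C4CCCCC4)cc3)CC2)C1=O` differs from compound 2 by (methanesulfonamido)methyl in place of hydroxy on a saturated chain carbon bound to an amide-type nitrogen. Among the compounds with values here, no measured step reproduces this change; the only step on the same carbonyl substituent is the one from compound 1 to compound 2, which has no parallel here, so no step beyond the scatter is expected in this assay. Compound 3 is estimated at 6000 nM (range 2000 nM to 20000 nM), a step of a 1.4-fold lower number from compound 2 to compound 3 (0.14 log units; within the scatter).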

Compound 3, half-maximal inhibitory concentration: 2100 nM
Beside the measured number, compound 3's estimate is 2.9-fold (0.46 log units) above it; the range from low to high includes it.
By their numbers in this assay, from the lowest: compounds 1 and 3 (each within the scatter of the next); then compound 2.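

In this assay, extending the chain on the amide-type nitrogen gives a 4.0-fold lower number from compound 2 to compound 3 (0.60 log units; beyond the scatter) and so recovers the ground lost with the hydroxymethyl group. With a 1.9-fold higher number from compound 1 to compound 3 (0.28 log units; within the scatter) inside the scatter, an open (2-(methanesulfonamido)ethyl)amino chain on this carbonyl carbon reads alike to the piperidin-1-yl ring. No measurement here explains this difference.

From the compounds shown here alone, whether the methanesulfonamido group or the ethyl chain alone carries the change stays open. Plain ethylamino, a 2-aminoethyl chain or a terminal carboxylic acid would separate the two.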